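The source may hold more compounds than are shown below. What is called first, only, known or untested is meant among the compounds shown, and "the series" means these compounds.

Compound 1 `Cc1nc2c(OCc3ccccc3)cccn2c1N`: 96%; compound 2 `Nc1cnc2c(OCc3ccccc3)cccn12`: 43%; compound 3 `CCCCc1nc2c(OCc3ccccc3)cccn2c1N`: 0%.

In a functional assay on the whole organism with Canis familiaris (Canis lupus familiaris) as the target, at a dose of 8 mg/kg by the oral route (on this read-out lower numbers stand for a weaker effect and higher numbers for a stronger effect at the one dose given), compound 3 stands lowest of the three measured numbers; its nearest neighbour is compound 2, and the furthest is compound 1. The two steps that lead to it are both large: a number 96 percentage points lower from compound 1 to compound 3 (beyond the scatter), and a number 43 percentage points lower from compound 2 to compound 3 (beyond the scatter). The step of a number 53 percentage points lower from compound 1 to compound 2 (beyond the scatter) is also beyond the scatter. Compound 4 `CC(C)(C)c1nc2c(OCc3ccccc3)cccn2c1N` differs from compound 3 in one place: tert-butyl in place of butyl on an aromatic carbon. Among the measured compounds shown here, no measured step swaps one four-carbon group for another, so the measured steps bear on this change only indirectly, in that every change at this aromatic carbon so far has shifted the read-out by a large amount, and compound 3 already lies at the bottom. Because compound 3 gives 0%, the number can only hold or rise. The expected step is a number 12 percentage points higher from compound 3 to compound 4 (beyond the scatter), a small move within or just beyond the scatter. Compound 4 is therefore estimated at 12%, with a range from 0% to 40%.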

Compound 4, a percentage reported as inhibition, in the whole organism at one dose (the size of the read-out at that dose, not a potency): 0%
Beside the measured number, compound 4's estimate is 12 percentage points above it, within the range that was stated.
By their numbers in this assay, from the lowest: compounds 3 and 4 (each within the scatter of the next); then compound 2; then compound 1.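

In this assay, joining the four carbons as tert-butyl rather than butyl on this aromatic carbon leaves the read-out unmoved, with no change at the digits printed from compound 3 to compound 4 (within the scatter), so among these compounds the arrangement of the chain makes no visible difference while the read-out stays at the bottom. The tert-butyl group matches butyl in falling short of the smaller substituents, with a number 43 percentage points lower from compound 2 to compound 4 (beyond the scatter) against hydrogen and a number 96 percentage points lower from compound 1 to compound 4 (beyond the scatter) against methyl, so both four-carbon groups lie well under hydrogen and methyl lies above them all. Nothing measured here accounts for this loss.

As far as these compounds go, it remains open where the read-out falls away between methyl and the four-carbon groups, as an ethyl or a propyl group on this carbon would show. Also open, from the compounds shown here alone, is how a hydroxymethyl or a methoxymethyl group would read at the same place.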